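The compounds below may be only part of what the source reports. "The series", "measured", "known", "first", "only" and "open" are said of these compounds alone.

Compound 1 `Cc1cc(C)c2cccc(OCc3c(Cl)ccc(S(=O)(=O)NC4(C(=O)N5CCN(C(=O)[C@@H](N)CCCC[N+](C)(C)C)CC5)CCCC4)c3Cl)c2n1` — in an assay on isolated protein for binding affinity to B1 bradykinin receptor (Homo sapiens) (on this read-out lower numbers stand for stronger inhibition and higher numbers for weaker inhibition), compound 1 gives < 10000 nM, which is a limit of the assay and not a number.
Compound 2 `Cc1cc(C)c2cccc(OCc3c(Cl)ccc(S(=O)(=O)NC4(C(=O)N5CCN(C(=O)[C@H](CCCCN)[N+](C)(C)C)CC5)CCCC4)c3Cl)c2n1` — in this assay compound 2 gives < 10000 nM, again a limit of the assay.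
Compound 3 `Cc1cc(C)c2cccc(OCc3c(Cl)ccc(S(=O)(=O)NC4(C(=O)N5CCN(C(=O)C[C@H](CCCN)[N+](C)(C)C)CC5)CCCC4)c3Cl)c2n1` — in this assay compound 3 gives < 10000 nM, also a limit of the assay.

Compound 3 therefore stands only at a limit, and the two further values shown are limits as well; all three sit together at the limit of < 10000 nM in this assay, at which 3 of the 3 values shown sit. The three measured steps, a step that the two limits leave unreadable from compound 1 to compound 2, a step that the two limits leave unreadable from compound 1 to compound 3 and a step that the two limits leave unreadable from compound 2 to compound 3, each swap one group of 10 heavy atoms for another on a carbonyl carbon, and none of them has a readable size since both of their ends are limits.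

Compound 4 `Cc1cc(C)c2cccc(OCc3c(Cl)ccc(S(=O)(=O)NC4(C(=O)N5CCN(C(=O)CCCC[N+](C)(C)C)CC5)CCCC4)c3Cl)c2n1` differs from compound 3 by a group of 7 heavy atoms (6 carbon, 1 nitrogen; no ring) in place of a group of 9 heavy atoms (7 carbon, 2 nitrogen; no ring), on a saturated chain carbon bound to a carbonyl carbon. The measured steps bear on this change only in that they rework the same group on the carbonyl carbon, and they give no size at all. With nothing readable to go on, compound 4 is expected to remain in the same region as compound 3, most likely reported at the limit once more. Compound 4 is estimated at 1000 nM, within a range from 30 nM to 10000 nM. The step this estimate implies is expected to be a step that the limit leaves unreadable from compound 3 to compound 4, with no direction beyond the scatter claimed.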

Compound 4, inhibition constant: < 10000 nM
Compound 4 ended at the assay's limit; the forecaster's own chance of this, stated with the estimate: 70%; the middle value is on the limit's open side.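

The steps from compound 1, compound 2 and compound 3 to compound 4 cannot be read, since each pair has limits of the assay at both ends in this assay: the limit of < 10000 nM in this assay, at which 4 of the 4 values shown sit.

The compounds shown leave open how strongly any of the four binds, and whether swapping these groups changes that at all.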